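Benzylamine in place of an ether on a shared core

The compounds below may be only part of what the source reports. "The series", "measured", "known", "first", "only" and "open" are said of these compounds alone.

Measured so far:
- compound 1, `CCC1(Cc2ccccc2)OS(=O)(=O)C=C1OCC#N`: in an ADME assay on HEL cells (Homo sapiens) for cytotoxicity, with a stated time of 3 days (a lower number here means that less compound is tolerated, a higher number that more compound is tolerated), compound 1 gives > 200000 nM, a limit of the assay.
- compound 2, `CCC1(Cc2ccccc2)OS(=O)(=O)C=C1OC`: in this assay compound 2 gives > 200000 nM, a limit of the assay.
- compound 3, `CCC1(Cc2ccccc2)OS(=O)(=O)C=C1OCC1CCCCC1`: in this assay compound 3 gives > 200000 nM, a limit of the assay.

Compound 3 therefore stands only at the limit of > 200000 nM in this assay, at which 3 of the 3 values shown sit, alongside the other two. The steps a step that the two limits leave unreadable from compound 1 to compound 3, a step that the two limits leave unreadable from compound 2 to compound 3 and a step that the two limits leave unreadable from compound 1 to compound 2 cannot be sized. Compound 4, `CCC1(Cc2ccccc2)OS(=O)(=O)C=C1NCc1ccccc1`, differs by benzylamino in place of cyclohexylmethoxy on a double-bonded ring carbon. With every measured step unreadable, no step beyond the scatter is expected from compound 3 to compound 4 in this assay, and the estimated step is a number no higher from compound 3 to compound 4 (the limit leaves the size open). Compound 4 is expected to give about 200000 nM, within 100000 nM to 400000 nM, most likely again as a limit.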

Compound 4, half-maximal cytotoxic concentration: 92000 nM
Compound 4: the middle estimate sits 2.2-fold (0.34 log units) above what was measured, and the stated range ends above it.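

Benzylamino on this double-bonded ring carbon is the only change shown that gives a readable value in this assay: in place of cyclohexylmethoxy it gives an at least 2.1-fold lower number from compound 3 to compound 4 (0.33 log units; beyond the scatter), in place of methoxy an at least 2.1-fold lower number from compound 2 to compound 4 (0.33 log units; beyond the scatter), and in place of cyanomethoxy an at least 2.1-fold lower number from compound 1 to compound 4 (0.33 log units; beyond the scatter). So the group at this position can lower the concentration tolerated, whereas the steps among the three ethers cannot be read: the limit of > 200000 nM in this assay, at which 3 of the 4 values shown sit.

Benzylamino brings in the nitrogen link and the aromatic ring together, so the compounds shown do not separate the two. Cyclohexylmethylamino or benzyloxy at this carbon would do so.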